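From compound 1 to compound 4: a longer chain

The source may hold more compounds than are shown below. What is called first, only, known or untested is meant among the compounds shown, and "the series" means these compounds.

Compound 1 (`CCCCC(CCO)n1cnc2c(Cl)ncnc21`) gives > 50000 nM in a functional assay on HCT-116 cells (Homo sapiens) for antiproliferative activity, read by MTT assay, with a stated time of 48 h (on this read-out lower numbers stand for stronger inhibition and higher numbers for weaker inhibition), and so stands at a limit, not at a number. Compound 3 (`CCCCC(CCO)n1cnc2c(N)ncnc21`) gives > 50000 nM in this assay and this is also a limit. Compound 2 (`CCCCC(CCO)n1cnc2c(Cl)nc(Cl)nc21`) gives 15500 nM in this assay as a real number.

The next compound, compound 4 (`CCCCCCC(CCO)n1cnc2c(Cl)ncnc21`), keeps the core of compound 1 and differs only in the chain (ethyl in place of hydrogen on a saturated chain carbon, five bonds along the chain from an aromatic nitrogen), with ethyl in place of hydrogen on a saturated chain carbon, five bonds along the chain from an aromatic nitrogen.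

Within the data shown here, no measured step touches that chain, so the evidence is indirect. Among the measured compounds shown here, the only readable step is an at least 3.2-fold lower number from compound 1 to compound 2 (0.50 log units; beyond the scatter) with chloro in place of hydrogen on an aromatic carbon. The other, a step that the two limits leave unreadable from compound 1 to compound 3 with amino in place of chloro on an aromatic carbon, gives no size. The starting point for compound 1 is only the limit of > 50000 nM in this assay, at which 2 of the 3 values shown sit, and nothing firmer.

A modest move toward a lower number is expected, no larger than the chloro step, and the estimated change is an at least 1.4-fold lower number from compound 1 to compound 4 (0.15 log units; that floor lies within the scatter) in size. In this assay compound 4 is estimated at 35000 nM with an expected range of 14000 nM to 80000 nM and may yet report only a limit.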

Compound 4, half-maximal inhibitory concentration: 11900 nM
Compound 4: middle estimate off by 2.9-fold (0.47 log units), on the high side; measured number below the stated range.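

Ethyl in place of hydrogen on a saturated chain carbon, five bonds along the chain from an aromatic nitrogen, gives an at least 4.2-fold lower number from compound 1 to compound 4 (0.62 log units; beyond the scatter), with the core of compound 1 left untouched. Among these compounds, until this result, the only readable step lay on an aromatic carbon of the core, so this is the first sign that the chain itself matters in this assay, and that a change there alone is enough to bring the series from a limit to a real number. The size of this step is only a floor, not a measured gap, because compound 1 has no number to start from: the limit of > 50000 nM in this assay, at which 2 of the 4 values shown sit.

The compounds shown leave open whether the effect keeps growing with a still longer chain, whether it depends on the hydroxyl at the chain end, which might instead be a carboxylic acid or an amine, and whether the longer chain and the added chloro of compound 2 would combine in a single compound. They also say nothing about how amino compares with chloro on the core, since that step cannot be read between its two limits.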